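The source may hold more compounds than are shown below. What is called first, only, known or untested is meant among the compounds shown, and "the series" means these compounds.

Measured so far:
Compound 1 `COc1ccc(-c2oc3c(OC)c(OC)cc(OCCCCC(=O)NCc4ccccn4)c3c(=O)c2O)cc1` gives > 40000 nM in a functional assay on MCF7 cells (Homo sapiens) for antiproliferative activity, read by sulforhodamine B assay, with a stated time of 48 h (on this read-out higher numbers stand for weaker inhibition and lower numbers for stronger inhibition), which is a limit of the assay rather than a number.
Compound 2 `COc1ccc(-c2oc3c(OC)c(OC)cc(OCCCCC(=O)N4CCN(C)CC4)c3c(=O)c2O)cc1` gives > 40000 nM in this assay, again a limit of the assay.
For the measured compounds named here, compound 3 `COc1ccc(-c2oc3c(OC)c(OC)cc(OCCCCCC(=O)N4CCN(C)CC4)c3c(=O)c2O)cc1` gives 14100 nM in this assay, the only true number among the three.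

All three compounds share one core and differ only in the chain that hangs from an oxygen on an aromatic ring and in the group at the end of that chain. Compound 2 becomes compound 1 through (((pyridin-2-yl)methyl)amino in place of 4-methylpiperazin-1-yl on a carbonyl carbon). The step that the two limits leave unreadable from compound 2 to compound 1 cannot be sized because the limit of > 40000 nM in this assay, at which 2 of the 3 values shown sit, holds both values. Compound 2 becomes compound 3 through (((4-methylpiperazin-1-yl)carbonyl)methyl in place of (4-methylpiperazin-1-yl)carbonyl on a saturated chain carbon, four bonds along the chain from an oxygen on an aromatic ring), a single extra chain carbon, and here the step of an at least 2.8-fold lower number from compound 2 to compound 3 (0.45 log units; beyond the scatter) is readable and shows the longer chain giving the stronger inhibition.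

Compound 4 `COc1ccc(-c2oc3c(OC)c(OC)cc(OCCCCCC(=O)NCc4ccccn4)c3c(=O)c2O)cc1` is the still unmeasured partner: it takes compound 3 and applies (((pyridin-2-yl)methyl)amino in place of 4-methylpiperazin-1-yl on a carbonyl carbon). The place of this change is worded exactly as for compound 2 to compound 1, so it is the same change, now made on the longer chain. Going by the values given here, its only earlier instance gave no readable size, so there is nothing to say whether it helps or hurts. The step of a 1.4-fold higher number from compound 3 to compound 4 (0.15 log units; within the scatter) is therefore expected to be small, with wide uncertainty and a real chance that the assay reports only a limit again. Compound 4 is expected to give 20000 nM, most likely between 8000 nM and 50000 nM.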

Compound 4, half-maximal inhibitory concentration: > 40000 nM
Compound 4: only a limit was reported; the forecaster's own chance of this, stated with the estimate: 40%; at least 2.0-fold (0.30 log units) between middle value and limit.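

In this assay compound 4 gives > 40000 nM, which is a limit of the assay and not a true number. On the longer chain, putting ((pyridin-2-yl)methyl)amino in place of 4-methylpiperazin-1-yl on the carbonyl carbon weakens inhibition, with an at least 2.8-fold higher number from compound 3 to compound 4 (0.45 log units; beyond the scatter), and this size is only a minimum, so the real loss could be larger. The same change on the shorter chain cannot be read, and neither can the other new steps that link compound 4 to compound 1 and compound 2, so the series does not show whether the change carries over from one chain length to the other with a similar size, because both members of each of these pairs sit at the same limit: the limit of > 40000 nM in this assay, at which 3 of the 4 values shown sit.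

From the compounds shown here alone, compound 3 alone gives a true number, so it remains open whether a still longer chain would bring the ((pyridin-2-yl)methyl)amino end group into the measurable range and allow the two end groups to be sized against each other. Going by these compounds, it is also open how a carboxylic acid or a morpholin-4-yl group at the end of the longer chain would compare with 4-methylpiperazin-1-yl.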